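Isopropyl to methyl on the benzyl ring of a coumarin series

This account rests on a few compounds, and the source may have more. Where it says the series, first, only, none or still open, it means among the compounds named here.

Of the compounds shown here, two built on a shared core have so far been measured in an ADME assay on isolated protein for inhibition of Amine oxidase [flavin-containing] A (Homo sapiens), read by fluorescence and Amplex Red, with stated times of 15 min and 20 min; on this read-out lower numbers stand for stronger inhibition and higher numbers for weaker inhibition. Compound 1 `C#CCN(CCCCOc1ccc2ccc(=O)oc2c1)Cc1ccc(OC)cc1` gives 54500 nM in this assay. Compound 2 `C#CCN(CCCCOc1ccc2ccc(=O)oc2c1)Cc1ccc(C(C)C)cc1` gives 35400 nM, the lowest of the two numbers, though the step of a 1.5-fold lower number from compound 1 to compound 2 (0.19 log units; within the scatter) lies within the scatter, so the two compounds cannot be ordered on these data. Compound 3 `C#CCN(CCCCOc1ccc2ccc(=O)oc2c1)Cc1ccc(C)cc1` has not yet been measured. It differs from compound 2 by methyl in place of isopropyl on an aromatic carbon. Among the compounds with values here, the only measured step that touches this place, a 1.5-fold lower number from compound 1 to compound 2 (0.19 log units; within the scatter), exchanged methoxy for isopropyl on an aromatic carbon and stayed within the scatter, and the present exchange leaves the same part of the molecule. Compound 3 is therefore expected to show a step of a 1.3-fold higher number from compound 2 to compound 3 (0.10 log units; within the scatter) in this assay, no larger than the scatter and with no firm direction. The estimate for compound 3 is 45000 nM, with a range from 18000 nM to 110000 nM.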

Compound 3, half-maximal inhibitory concentration: 94500 nM
Estimate against measurement, compound 3: 2.1-fold (0.32 log units) below; the measured number falls inside the stated range.
By their numbers in this assay, from the lowest: compounds 2, 1 and 3 (each within the scatter of the next, the first and the last beyond it).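

The group at this place on the benzyl ring now gives its first step beyond the scatter in this assay: replacing isopropyl with methyl gives a 2.7-fold higher number from compound 2 to compound 3 (0.43 log units; beyond the scatter) (modest in size). Methyl and methoxy cannot be told apart here, as the exchange gives a 1.7-fold higher number from compound 1 to compound 3 (0.24 log units; within the scatter) and stays within the scatter, so only the pair of compound 2 and compound 3 separates on these data. No measurement presented here accounts for the step between them.

Three groups are too few to show whether the number follows the size of the carbon group at this place. An ethyl or tert-butyl group, or a bare hydrogen on the same aromatic carbon, would show whether the step between isopropyl and methyl extends to other groups.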